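Notes on compound 4 against three measured analogues

This account rests on a few compounds, and the source may have more. Where it says the series, first, only, none or still open, it means among the compounds named here.

The series shares one core, varied at the group attached to an aromatic carbon of the six-membered ring with one nitrogen. Compound 1 `CCCCOc1nc(C(C)(C)C)ccc1CNC(=O)C(C)c1ccc(NS(C)(=O)=O)c(F)c1` gives 0.9 nM in an assay on cells for antagonist activity at transient receptor potential cation channel subfamily V member 1 (Homo sapiens), read by FLIPR and calcium flux, with a stated time of 6 min; on this read-out lower numbers stand for stronger inhibition and higher numbers for weaker inhibition. Compound 2 `CC(C)COc1nc(C(C)(C)C)ccc1CNC(=O)C(C)c1ccc(NS(C)(=O)=O)c(F)c1` gives 0.6 nM in this assay, a difference recorded as a 1.5-fold lower number from compound 1 to compound 2 (0.18 log units; within the scatter). Compound 3 `CC(C(=O)NCc1ccc(C(C)(C)C)nc1OC1CCCCC1)c1ccc(NS(C)(=O)=O)c(F)c1` gives 2.5 nM in this assay, the highest of the three numbers; the nearest is compound 1, with a 2.8-fold higher number from compound 1 to compound 3 (0.44 log units; beyond the scatter), and the furthest is compound 2, with a 4.2-fold higher number from compound 2 to compound 3 (0.62 log units; beyond the scatter).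

Compound 4 `CC(C(=O)NCc1ccc(C(C)(C)C)nc1SCCCN(C)C)c1ccc(NS(C)(=O)=O)c(F)c1` has not been measured. It differs from compound 3 in one place: (3-(dimethylamino)propyl)sulfanyl in place of cyclohexyloxy on an aromatic carbon. All three measured steps touch the same position, yet each only reshapes a saturated carbon group on an oxygen on the aromatic ring, and the largest of them is modest. Going by the values given here, the change to compound 4 exchanges the oxygen as well as the carbon group, so no measured step covers it directly. The measured steps show that the group at this position moves the number only modestly; a change of this extent is expected to move it somewhat further, and with the numbers rising from compound 1 and compound 2 to compound 3, the direction is taken as a higher number. The step is estimated as a 2.8-fold higher number from compound 3 to compound 4 (0.45 log units; beyond the scatter). Compound 4 is therefore expected to give about 7 nM in this assay, within a range from 1.5 nM to 35 nM.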

Compound 4, inhibition constant: 51.8 nM
Compound 4: middle estimate off by 7.4-fold (0.87 log units), on the low side; measured number above the stated range.
By their numbers in this assay, from the lowest: compounds 2 and 1 (each within the scatter of the next); then compound 3; then compound 4.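

At this position, on an aromatic carbon next to the ring nitrogen, replacing cyclohexyloxy with (3-(dimethylamino)propyl)sulfanyl gives in this assay a 21-fold higher number from compound 3 to compound 4 (1.32 log units; beyond the scatter), a large step, whereas the steps among the three earlier compounds were modest at most. The steps from the two open-chain ethers are large as well, with a 58-fold higher number from compound 1 to compound 4 (1.76 log units; beyond the scatter) and an 86-fold higher number from compound 2 to compound 4 (1.94 log units; beyond the scatter), so the tolerance seen across butoxy, isobutoxy and cyclohexyloxy does not extend to this replacement. No measurement available here bears on the cause of this rise.

As far as these compounds go, compound 4 exchanges the oxygen for sulfur and the carbon group for a chain ending in a dimethylamino group in a single step, so the share of each change in the rise remains open. A butylsulfanyl group, which keeps the sulfur without the amine, and a 3-(dimethylamino)propoxy group, which keeps the amine on an oxygen, would separate the two, while a shorter aminoalkyl chain or a morpholine at the chain end would show whether the length of the chain or the form of the amine matters.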